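Shortening the ester tail in a kinase inhibitor series

This account rests on a few compounds, and the source may have more. Where it says the series, first, only, none or still open, it means among the compounds named here.

Compound 1 `CCCCOC(=O)c1cccc(-c2cc(C(=O)Nc3ccncc3)ccc2CN)c1` — 5.5 nM
Compound 2 `NCc1ccc(C(=O)Nc2ccncc2)cc1-c1cccc(C(=O)OCC2CCCC2)c1` — 5 nM

Both compounds share one core and differ only in the saturated chain carried by the ester oxygen. In an assay on isolated protein for inhibition of Rho-associated protein kinase 2 (Homo sapiens), read by radiometric assay (a lower number here means a stronger inhibitor, a higher number a weaker inhibitor), compound 1 gives 5.5 nM and compound 2 gives 5 nM. Compound 2 shows the lowest of the two numbers, yet the step of a 1.1-fold lower number from compound 1 to compound 2 (0.04 log units; within the scatter) is too small to set the two apart, so neither can be called the stronger inhibitor.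

Compound 3 `CCOC(=O)c1cccc(-c2cc(C(=O)Nc3ccncc3)ccc2CN)c1` is the next variation on this same chain: methyl in place of cyclopentyl on a saturated chain carbon bound to an oxygen next to a carbonyl group. Within the data shown here, the one measured step that touches this position, a 1.1-fold lower number from compound 1 to compound 2 (0.04 log units; within the scatter), exchanged one saturated chain for another on the oxygen next to the carbonyl and moved the number hardly at all. Among the measured compounds shown here, that single comparison is the only guide available, and it points to this ester tail tolerating change. The expected step is therefore none beyond the scatter, a 1.6-fold higher number from compound 2 to compound 3 (0.20 log units; within the scatter), perhaps with a slight drift toward a higher number for the much shorter chain. Compound 3 is expected to give about 8 nM in this assay, with a range from 3 nM to 25 nM.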

Compound 3, half-maximal inhibitory concentration: < 1 nM
Compound 3: no number, only a limit; the forecaster's own chance of this, stated with the estimate: 0%; at least 8.0-fold (0.90 log units) between middle value and limit.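

Among these compounds, the ester tail is less indifferent than the first pair of compounds suggested: in this assay, replacing cyclopentylmethoxycarbonyl with ethoxycarbonyl gives an at least 5.0-fold lower number from compound 2 to compound 3 (0.69 log units; beyond the scatter). Cutting the straight chain back to ethyl tells the same story, with an at least 5.5-fold lower number from compound 1 to compound 3 (0.74 log units; beyond the scatter), so both larger tails, which could not be separated from each other, lose out to the ethyl ester, and this position does respond to the size of the chain once it becomes short enough. Compound 3 is recorded only as a limit of the assay and not as a number, so both steps give a minimum size and not a full one: the limit of < 1 nM in this assay, at which 1 of the 3 values shown sits.

From the compounds shown here alone, how much stronger compound 3 really is stays open, and three tails cannot show whether the shortest chain here is the best one or simply the first to stand apart from the larger ones. A methyl ester, a propyl ester or the free carboxylic acid in the same place would show whether the number keeps dropping as the chain shortens and whether the ester itself is needed at all.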